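Sulfonylpiperidine series: removing the benzyl substituent

The compounds below may be only part of what the source reports. "The series", "measured", "known", "first", "only" and "open" are said of these compounds alone.

Within the data shown here, in a functional assay on DLD-1 cells (Homo sapiens) for antiproliferative activity, read by CellTiter-Glo, with a stated time of 72 h (on this read-out higher numbers stand for weaker inhibition and lower numbers for stronger inhibition), compound 3 `Cc1cc(C)c(S(=O)(=O)N2CCC(N3CCC(Cc4ccccc4)CC3)CC2)c(C)c1` gives 3.5 nM, the second highest of the three numbers so far. Its nearest neighbour is compound 1 `Cc1cc(C)c(S(=O)(=O)N2CCC(N3CCC(C(C)C)CC3)CC2)c(C)c1`, which gives 0.3 nM; that gap is a 12-fold higher number from compound 1 to compound 3 (1.07 log units; beyond the scatter). Furthest from it is compound 2 `Cc1cc(C)c(S(=O)(=O)N2CCC(N3CCC(Cc4ccccc4F)CC3)CC2)c(C)c1`, which gives 74 nM; that gap is a 21-fold lower number from compound 2 to compound 3 (1.33 log units; beyond the scatter). The remaining step, a 250-fold higher number from compound 1 to compound 2 (2.39 log units; beyond the scatter), is the largest in the set.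

Compound 4 `Cc1cc(C)c(S(=O)(=O)N2CCC(N3CCCCC3)CC2)c(C)c1` differs from compound 3 by hydrogen in place of benzyl on a saturated ring carbon. Among the measured compounds shown here, no measured step removes the substituent on that ring carbon altogether, so the expectation rests on the neighbours: the smaller group in compound 1 gives the lowest number, the larger group in compound 2 the highest. Taking that at face value, the number for compound 4 is expected to stay near that of compound 3, with a wide range, so a 1.1-fold higher number from compound 3 to compound 4 (0.06 log units; within the scatter) is the expected step. For compound 4 the estimate in this assay is 4 nM, between 0.4 nM and 40 nM.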

Compound 4, half-maximal inhibitory concentration: 2200 nM
Compound 4: middle estimate off by 550-fold (2.74 log units), on the low side; the measured number lies above the stated range.
By their numbers in this assay, from the lowest: compound 1; then compound 3; then compound 2; then compound 4.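

Hydrogen on this saturated ring carbon gives the highest number of the four compounds in this assay. The step is a 630-fold higher number from compound 3 to compound 4 (2.80 log units; beyond the scatter) when benzyl leaves, a 30-fold higher number from compound 2 to compound 4 (1.47 log units; beyond the scatter) when 2-fluorobenzyl leaves and a 7300-fold higher number from compound 1 to compound 4 (3.87 log units; beyond the scatter) when isopropyl leaves, all beyond the scatter. The earlier compounds shown here only ranked three groups against one another, whereas compound 4 shows that each of them, even the 2-fluorobenzyl of compound 2, gives a lower number than hydrogen, so within these four compounds a carbon substituent at this place counts for more than the choice among the three. Nothing at hand explains the size of this loss.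

On these data alone, how small a group can be and still give a low number stays open, for instance methyl or ethyl. So does the response to a group carrying an amine or a carboxylic acid at this carbon.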